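A few compounds are considered here, and "the series" means these few. Any claim that something is new, unique, unknown or untested is made for them only; others in the source may bear on it.

Measured compounds in a functional assay on cells (leukaemia cell line, Homo sapiens) for inhibition, read by sulforhodamine B assay, with a stated time of 48 h; a higher number here means a weaker inhibitor of growth, a lower number a stronger inhibitor of growth:
compound 1, `O=S(=O)(Nc1ccc(Cl)cc1Cl)c1ccc(-c2cnc(C3CC3)o2)cc1`, gives 74500 nM
compound 2, `O=S(=O)(Nc1ccccc1Cl)c1ccc(-c2cnc(C3CC3)o2)cc1`, gives 49700 nM
compound 3, `Cc1cc(NS(=O)(=O)c2ccc(-c3cnc(C4CC4)o3)cc2)ccc1Cl`, gives 33400 nM

Compound 3 carries the lowest number of the three. Compound 2 lies within the scatter of it, as a 1.5-fold lower number from compound 2 to compound 3 (0.17 log units; within the scatter) shows, while compound 1 sits further off: a 2.2-fold lower number from compound 1 to compound 3 (0.35 log units; beyond the scatter), a modest step beyond the scatter.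

Compound 4, `Cc1cc(Cl)ccc1NS(=O)(=O)c1ccc(-c2cnc(C3CC3)o2)cc1`, is not yet measured. It differs from compound 3 only in the substituted ring on the sulfonamide nitrogen: 4-chloro-2-methylphenyl in place of 4-chloro-3-methylphenyl on a sulfonamide nitrogen.

Within the data shown here, the steps that bear on this are those which alter the same ring. Removing one chloro from it, a 1.5-fold lower number from compound 1 to compound 2 (0.18 log units; within the scatter), stayed within the scatter. Exchanging the whole substitution pattern, a 2.2-fold lower number from compound 1 to compound 3 (0.35 log units; beyond the scatter) and a 1.5-fold lower number from compound 2 to compound 3 (0.17 log units; within the scatter), gave at most a modest step. Moving the methyl while the chloro is kept is a change of the same kind, and nothing in the series points to a larger response in this assay for compound 4 than those steps produced. The expected step, a 1.1-fold higher number from compound 3 to compound 4 (0.06 log units; within the scatter), is therefore none beyond the scatter. Compound 4 is estimated at 38000 nM, with a range of 16000 nM to 90000 nM.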

Compound 4, concentration for total growth inhibition: 54700 nM
Compound 4: the middle estimate sits 1.4-fold (0.16 log units) below what was measured, within the range that was stated.
By their numbers in this assay, from the lowest: compounds 3, 2, 4 and 1 (each within the scatter of the next, the first and the last beyond it).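

In this assay, among these compounds, moving the methyl around the ring on the sulfonamide nitrogen while the chloro is kept (a 1.6-fold higher number from compound 3 to compound 4 (0.21 log units; within the scatter)) is a change this position absorbs within the scatter, and this is the first reading of a methyl shift with nothing else altered. Putting methyl in place of chloro on a single aromatic carbon (a 1.4-fold lower number from compound 1 to compound 4 (0.13 log units; within the scatter)) also stays within the scatter, and the step from the 2-chlorophenyl group to the 4-chloro-2-methylphenyl group (a 1.1-fold higher number from compound 2 to compound 4 (0.04 log units; within the scatter)) does the same. Compound 4 therefore lies within the scatter of compound 1, compound 2 and compound 3 alike, so the one separation printed in the series, between compound 1 and compound 3, is not matched by any step involving compound 4.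

No measurement at hand accounts for how closely these ring patterns read. From the compounds shown here alone, whether an amine or a carboxylic acid on this ring, or a longer chain such as propyl in place of the methyl, would produce a step beyond the scatter stays open.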